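Compound 4: methoxy in place of hydrogen on compound 3

A few compounds are considered here, and "the series" means these few. Any claim that something is new, unique, unknown or untested is made for them only; others in the source may bear on it.

In a functional assay on PC-3 cells (Homo sapiens) for cytotoxicity, read by WST assay, with a stated time of 48 h (on this read-out lower numbers stand for stronger inhibition and higher numbers for weaker inhibition), compound 1 `COc1ccc2c(/C=C(\C#N)C(=O)c3c[nH]c4cc(OC)ccc34)c[nH]c2c1` gives 27000 nM. Compound 2 `N#C/C(=C\c1c[nH]c2cc(F)ccc12)C(=O)c1c[nH]c2cc(F)ccc12` reaches only a limit, > 50000 nM. Compound 3 `N#C/C(=C\c1c[nH]c2cc(F)ccc12)C(=O)c1c[nH]c2ccccc12` also reaches only a limit, > 50000 nM. Compound 3 therefore has no number and stands at the limit of > 50000 nM in this assay, at which 2 of the 3 values shown sit. For the measured compounds named here, the only measured step, a step that the two limits leave unreadable from compound 2 to compound 3, gives no usable size.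

Compound 4 `COc1ccc2c(C(=O)/C(C#N)=C/c3c[nH]c4cc(F)ccc34)c[nH]c2c1` carries methoxy in place of hydrogen on an aromatic carbon. Going by the values given here, no measured step isolates this change. Among the compounds with values here, the only indirect support is compound 1, the one measured compound with methoxy and the only one with a number, 27000 nM. On that single value, a modest move toward stronger inhibition in this assay is expected, and another limit remains quite possible. The expected change is an at least 1.3-fold lower number from compound 3 to compound 4 (0.11 log units; that floor lies within the scatter). For compound 4, the estimated value is 38000 nM, with an expected range of 15000 nM to 70000 nM.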

Compound 4, half-maximal inhibitory concentration: 22500 nM
Beside the measured number, compound 4's estimate is 1.7-fold (0.23 log units) above it; the range from low to high includes it.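

In this assay, methoxy in place of hydrogen on this aromatic carbon gives the first readable move away from the limit: an at least 2.2-fold lower number from compound 3 to compound 4 (0.34 log units; beyond the scatter). Methoxy in place of fluoro at the same carbon gives an at least 2.2-fold lower number from compound 2 to compound 4 (0.34 log units; beyond the scatter), and both sizes are only floors, since each step starts from a compound without a number: the limit of > 50000 nM in this assay, at which 2 of the 4 values shown sit. With this methoxy kept, fluoro in place of the second methoxy gives a 1.2-fold lower number from compound 1 to compound 4 (0.08 log units; within the scatter), so a second methoxy adds nothing readable here.

On these data alone, whether an amine, a hydroxy group or a longer chain such as ethoxy at this carbon would move the number further remains open. Also open, as far as these compounds go, is whether the gain belongs to methoxy alone, as only methoxy, fluoro and hydrogen are compared at this carbon.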